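This account rests on a few compounds, and the source may have more. Where it says the series, first, only, none or still open, it means among the compounds named here.

Measured compounds:
- compound 1 `COc1cc(Nc2nc(C(=N)Nc3ccc(N4CCN(C)CC4)cc3)cc3c(-c4ccccc4)n[nH]c23)cc(OC)c1OC` — "not determined" (no result reported) in an ADME assay on AG1523 cells (Homo sapiens) for cytotoxicity, read by MTT assay, with a stated time of 72 h; a lower number here means a stronger inhibitor, a higher number a weaker inhibitor
- compound 2 `COc1ccc(Cn2nc(-c3ccccc3)c3cc(C(=N)Nc4ccc(N5CCN(C)CC5)cc4)nc(Nc4cc(OC)c(OC)c(OC)c4)c32)cc1` — 1810 nM

Going by the values given here, compound 2 is the only compound here with a number in this assay; compound 1 was tested in the same study but no single value was reported for it, so there is nothing to set compound 2 against. Its concentration for half-maximal inhibition of the cell growth read-out therefore stands alone, in the micromolar region.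

Compound 3 `COc1ccc(Cn2nc(-c3ccccc3)c3cc(C(=N)Nc4ccc(N5CCN(C)CC5)cc4)nc(NC4CCCCC4)c32)cc1` is not yet measured. It differs from compound 2 in one place: cyclohexyl in place of 3,4,5-trimethoxyphenyl on a nitrogen on an aromatic ring. Everything else, including the shared core, the phenyl group, the amidine link and the methylpiperazinyl-bearing ring, is kept.

Among the compounds with values here, no step between two measured compounds is available to show what such a change does in this assay. Within the data shown here, with only the single value of compound 2 to rest on, the expectation is a modest change at most, possibly one that stays within the usual scatter, with a slight lean toward weaker inhibition, as a 1.5-fold higher number from compound 2 to compound 3 (0.19 log units; within the scatter). Compound 3 is accordingly estimated at 2800 nM, with a range from 800 nM to 12000 nM.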

Compound 3, half-maximal inhibitory concentration: 3330 nM
Compound 3: the middle estimate sits 1.2-fold (0.08 log units) below what was measured, within the range that was stated.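

In this assay, this position now has its first measured step: cyclohexyl in place of 3,4,5-trimethoxyphenyl on the nitrogen gives a 1.8-fold higher number from compound 2 to compound 3 (0.26 log units; within the scatter). The aromatic ring and the hydrogen-bond acceptors of the leaving group are gone, yet the two compounds cannot be told apart in this read-out, so for this one pair neither feature is shown to be needed for the micromolar level seen here. No measurement at hand gives a reason for this result.

Still open, going by these compounds, is whether a much smaller group on this nitrogen, such as methyl, or a different kind of group, such as a chain ending in a carboxylic acid or an amine, would also stay within the scatter or would move the number clearly. A single pair also cannot say whether the same tolerance would hold if other parts of the shared core were changed, so no general rule for this position follows yet.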